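A few compounds are considered here, and "the series" means these few. Any claim that something is new, unique, unknown or untested is made for them only; others in the source may bear on it.

Measured so far in a functional assay on OVCAR-5 cells (Homo sapiens) for inhibition, read by CCK-8 assay, with a stated time of 72 h, tested at 10 uM; on this read-out higher numbers stand for more inhibition of growth at the one concentration tested and lower numbers for less inhibition of growth:
- Compound 1 `CN(C)C(=O)c1cc2cnc(Nc3ccc(NC(=O)C4(C(=O)Nc5cccc(O)c5)CC4)cc3)nc2n1C1CCCC1`: 86%
- Compound 2 `CN(C)C(=O)c1cc2cnc(Nc3ccc(NC(=O)C4(C(=O)Nc5cccc(Cl)c5)CC4)cc3)nc2n1C1CCCC1`: 88.1%
- Compound 3 `CN(C)C(=O)c1cc2cnc(Nc3ccc(NC(=O)C4(C(=O)Nc5ccc(Cl)c(C(F)(F)F)c5)CC4)cc3)nc2n1C1CCCC1`: 48%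

Compound 1 cannot be separated from its nearest neighbour, with a number 2.1 percentage points higher from compound 1 to compound 2 (within the scatter). Its furthest neighbour is clearly apart, with a number 38 percentage points lower from compound 1 to compound 3 (beyond the scatter).

The next compound to be tested is compound 4 `CN(C)C(=O)c1cc2cnc(Nc3ccc(NC(=O)C4(C(=O)Nc5ccc(O)cc5)CC4)cc3)nc2n1C1CCCC1`. It has the same atoms as compound 1, joined differently: 4-hydroxyphenyl in place of 3-hydroxyphenyl on an amide-type nitrogen. In words, 4-hydroxyphenyl takes the place of 3-hydroxyphenyl on an amide-type nitrogen.

Going by the values given here, no measured pair shows this exact change, so only two steps offer indirect guidance. Chloro in place of hydroxy on an aromatic carbon gave a number 2.1 percentage points higher from compound 1 to compound 2 (within the scatter), which suggests that this part of the molecule can change without a clear loss. The 4-chloro-3-(trifluoromethyl)phenyl group in place of 3-hydroxyphenyl gave a number 38 percentage points lower from compound 1 to compound 3 (beyond the scatter). That group is the only measured one with a substituent named at the 4 place, but it also differs in other ways, and the data cannot separate these differences.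

The estimated step in this assay is a number 8 percentage points lower from compound 1 to compound 4 (within the scatter), a small downward step with real uncertainty. For compound 4 the estimate is 78%, with an expected range of 55% to 92%.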

Compound 4, percent growth inhibition at one concentration: 90.9%
Compound 4: the middle estimate sits 12.9 percentage points below what was measured, and the stated range covers the measured number.
By their numbers in this assay, from the lowest: compound 3; then compounds 1, 2 and 4 (each within the scatter of the next).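

Moving the hydroxy group, so that 4-hydroxyphenyl replaces 3-hydroxyphenyl on the amide-type nitrogen, gives a step within the scatter in this assay (a number 4.9 percentage points higher from compound 1 to compound 4 (within the scatter)), and 4-hydroxyphenyl also cannot be separated from the 3-chlorophenyl group (a number 2.8 percentage points higher from compound 2 to compound 4 (within the scatter)), so compounds 1, 2 and 4 stand level and this ring tolerates a hydroxy group at either of these two places. The large gap to the 4-chloro-3-(trifluoromethyl)phenyl group (a number 42.9 percentage points higher from compound 3 to compound 4 (beyond the scatter)) shows that a substituent at the 4 place does not by itself bring the low number of compound 3, which leaves the chloro and trifluoromethyl groups of that compound, alone or together, as the remaining differences. No measurement at hand explains why these numbers fall as they do.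

Still open is which of those two groups accounts for the loss, a question that 4-chlorophenyl and 3-(trifluoromethyl)phenyl on the same nitrogen would address. On these data alone, it is also open whether a 4-aminophenyl group or a 4-carboxyphenyl group would stay level with compound 4, and a single tested concentration cannot show whether compounds 1, 2 and 4 would still stand level at lower concentrations.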